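The source may report more compounds than this note shows. Statements on the series, on what has been measured and on what is new or still open speak of the compounds shown alone.

Working notes on the series.

Compound 1 `C=CCOc1ccc(C(=O)/C=C/c2cc(OC)cc(OC)c2)cc1` gives 25000 nM in a functional assay (Homo sapiens) for inhibition (on this read-out higher numbers stand for weaker inhibition and lower numbers for stronger inhibition), and is the lowest number among the three measured compounds. Compound 3 `C=CCOc1ccc(C(=O)/C=C/c2c(OC)cccc2OC)cc1` gives 96000 nM in this assay, and compound 2 `CCCCOc1ccc(C(=O)/C=C/c2c(OC)cccc2OC)cc1` gives 127000 nM in this assay. Compound 1 and compound 3 share the same atoms joined differently; the difference between the two cores is not broken down here.

For the measured compounds named here, the one step measured within a common core is a 1.3-fold higher number from compound 3 to compound 2 (0.12 log units; within the scatter), made by propyl in place of vinyl on a saturated chain carbon bound to an oxygen on an aromatic ring. It is a small step and stays within the scatter.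

Compound 4 `CCCCOc1ccc(C(=O)/C=C/c2cc(OC)cc(OC)c2)cc1` is not yet measured in this assay. It differs from compound 1 by propyl in place of vinyl on a saturated chain carbon bound to an oxygen on an aromatic ring, the same change as between compound 3 and compound 2, at a place described in the same words. Going by the values given here, on the single precedent of the step from compound 3 to compound 2 in this assay, a step of similar size is expected, namely a 1.3-fold higher number from compound 1 to compound 4 (0.11 log units; within the scatter); this rests on one pair only and carries the uncertainty of a single comparison.

Compound 4 is therefore estimated at 32000 nM in this assay, expected to fall between 14000 nM and 70000 nM.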

Compound 4, half-maximal inhibitory concentration: 52000 nM
The estimate for compound 4 lay 1.6-fold (0.21 log units) below the measured number, and the stated range covers the measured number.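

On the core of compound 1, allyloxy to butoxy gives a 2.1-fold higher number from compound 1 to compound 4 (0.32 log units; beyond the scatter) in this assay. Set beside the same change on the other core, the two steps do not differ: the same change on two cores in this assay, a 1.3-fold higher number (0.12 log units; within the scatter) from compound 3 to compound 2 and a 2.1-fold higher number (0.32 log units; beyond the scatter) from compound 1 to compound 4, 1.6-fold (0.20 log units) apart, within the scatter of two such steps. The change therefore carries from one core to the other with no difference that these data can resolve, but this rests on two pairs only, and since just one of the two steps lies beyond the scatter, the pairs fix neither a firm size for the change nor its behaviour on any third core.

The compounds shown leave open how this assay reads when the chain on the oxygen is replaced by a longer chain such as hexyl, or when it ends in an amine or a carboxylic acid. They also leave open whether allyl to butyl keeps a similar size on a core other than these two.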